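Phenyl in Place of Pyridin-3-yl: A Cell Toxicity Estimate

The source may hold more compounds than are shown below. What is called first, only, known or untested is meant among the compounds shown, and "the series" means these compounds.

Before a compound goes further, it helps to know how much of it harms living cells. In an ADME assay on LLC-MK2 cells (Macaca mulatta) for cytotoxicity, read by spectrophotometry and crystal violet staining, with a stated time of 4 days (on this read-out lower numbers stand for higher toxicity in this test and higher numbers for lower toxicity in this test), compound 1 `CC(C)n1ncc2c(C(=O)Nc3ccccc3F)cc(-c3cccnc3)nc21` reads 50000 nM and compound 2 `CC(C)n1ncc2c(C(=O)Nc3cc(F)ccc3F)cc(-c3cccs3)nc21` reads 100000 nM and these values sit within the usual scatter of each other, so repeat runs could not tell them apart. Among the measured compounds shown here, compound 1 therefore stands level with compound 2 on the numbers so far. Compound 3 `CC(C)n1ccc2c(C(=O)Nc3ccc(F)cc3)cc(-c3cccs3)nc21` reads > 200000 nM as a limit and not as a number.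

Compound 4 `CC(C)n1ncc2c(C(=O)Nc3ccccc3F)cc(-c3ccccc3)nc21` is still unmeasured. It differs from compound 1 in one place, with phenyl in place of pyridin-3-yl on an aromatic carbon while the rest of the structure stays the same. For the measured compounds named here, no pair of measured compounds differs in only one place, so no measured step can guide this swap. The expectation in this assay therefore starts from compound 1 at 50000 nM and foresees no shift beyond the scatter in either direction. The expected step is a 1.2-fold higher number from compound 1 to compound 4 (0.08 log units; within the scatter) and it stays within that scatter. For compound 4 the estimate is 60000 nM with a likely range from 20000 nM to 200000 nM once it is measured.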

Compound 4, half-maximal cytotoxic concentration: > 200000 nM
Compound 4: only a limit was reported (the forecaster's own chance of this, stated with the estimate: 25%); middle value at least 3.3-fold (0.52 log units) from the limit.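

In this assay, among the compounds shown here, the change at this position, the aromatic carbon next to the ring nitrogen, gives the first step that can be read between two compounds differing in one place: an at least 4.0-fold higher number from compound 1 to compound 4 (0.60 log units; beyond the scatter). Higher numbers stand for lower toxicity in this test, so replacing pyridin-3-yl with phenyl, which leaves the rest of the structure untouched, is not a neutral swap here and moves the compound toward lower toxicity. Compound 4 reads > 200000 nM, which is a limit and not a number, so the step gives only a minimum size and its true size stays unknown: the limit of > 200000 nM in this assay, at which 2 of the 4 values shown sit.

A single pair cannot show whether losing the nitrogen of pyridin-3-yl is what matters, and it leaves open how an aminomethyl group, a carboxylic acid or a longer alkyl chain at this position would read in this assay. It also leaves open whether the same swap would give a similar step in compounds that carry a different group on the amide.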